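Widening the Alkynyl Ring of Compound 1

This account rests on a few compounds, and the source may have more. Where it says the series, first, only, none or still open, it means among the compounds named here.

Compound 1 `O=C(O)CCc1ccc(C#CC2CC2)cc1` gives the highest maximal response of the three measured compounds in a functional assay on 1321-N1 cells for agonist activity at Free fatty acid receptor 1 (Homo sapiens), read by calcium flux, with a stated time of 0.4 s (on this read-out higher numbers stand for larger maximal responses and lower numbers for smaller maximal responses), reaching 128%. Compound 2 `C/C(C#Cc1ccc(CCC(=O)O)c(F)c1)=C/CO` gives 105% in this assay, and compound 3 `C/C=C\C#Cc1ccc(CCC(=O)O)c(F)c1` gives 91%. Going by the values given here, the only measured step between neighbours, a number 14 percentage points lower from compound 2 to compound 3 (beyond the scatter), concerns a different group on the triple-bonded carbon and a different core, so it bears only loosely on the change at hand. Compound 4 `O=C(O)CCc1ccc(C#CC2CCCCC2)cc1` differs from compound 1 by cyclohexyl in place of cyclopropyl on a triple-bonded carbon. Among the compounds with values here, no measured step tests this exchange directly; since the one exchange at the same place moved the response modestly, a step of similar size in either direction, or none beyond the scatter, is expected. The estimated value for compound 4 in this assay is 115%, within 85% to 140%, which is expected to mean a number 13 percentage points lower from compound 1 to compound 4 (beyond the scatter).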

Compound 4, largest response reached (reported as efficacy), in percent of the reference or control that the assay uses: 98%
Beside the measured number, compound 4's estimate is 17 percentage points above it; the range from low to high includes it.
By their numbers in this assay, from the lowest: compounds 3, 4 and 2 (each within the scatter of the next, the first and the last beyond it); then compound 1.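

In this assay the exchange of cyclopropyl for cyclohexyl on a triple-bonded carbon, with the core unchanged, gives a number 30 percentage points lower from compound 1 to compound 4 (beyond the scatter), so the size of the carbon ring at this place bears on the maximal response. The earlier compounds shown here, which also differ in the core, could not show this. No evidence is available to explain the fall. As far as these compounds go, it remains open whether cyclobutyl or cyclopentyl would give a response between those of these two rings, and whether a cyclohexyl ring carrying a hydroxyl or an amine would restore it.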